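The source may hold more compounds than are shown below. What is called first, only, known or untested is meant among the compounds shown, and "the series" means these compounds.

Measured in a functional assay on HeLa cells (Homo sapiens) for cytotoxicity, read by neutral red uptake, with a stated time of 3 days; a higher number here means a weaker inhibitor, a lower number a stronger inhibitor:
Compound 1 `Nc1ccc(-c2cc(=O)c3c(N)c(F)c(Br)c(F)c3o2)cc1F` sits at the limit of this assay, > 100000 nM.
Compound 2 `Nc1ccc(-c2cc(=O)c3c(N)c(F)c(Cl)c(F)c3o2)cc1F` also sits at the limit of this assay, > 100000 nM.
Compound 3 `Nc1ccc(-c2cc(=O)c3c(N)c(F)c(N)c(F)c3o2)cc1F` gives 19000 nM.

For the measured compounds named here, compound 3 therefore carries the only actual number in this assay; the other two values are limits. The change from compound 3 to compound 4 `CCCOCc1c(F)c(N)c2c(=O)cc(-c3ccc(N)c(F)c3)oc2c1F` is propoxymethyl in place of amino on an aromatic carbon. Going by the values given here, two measured steps touch the same position: an at least 5.2-fold lower number from compound 1 to compound 3 (0.72 log units; beyond the scatter) and an at least 5.2-fold lower number from compound 2 to compound 3 (0.72 log units; beyond the scatter), each descending to the number of compound 3 from the limit of > 100000 nM in this assay, at which 2 of the 3 values shown sit. Replacing the amino group with a propoxymethyl group moves away from the one substituent that produced a readable number, so a higher number in this assay is expected for compound 4, estimated at 60000 nM with a range from 15000 nM to 200000 nM. That estimate corresponds to a 3.2-fold higher number from compound 3 to compound 4 (0.50 log units; beyond the scatter).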

Compound 4, half-maximal inhibitory concentration: 78000 nM
Estimate against measurement, compound 4: 1.3-fold (0.11 log units) below; the measured number falls inside the stated range.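

In this assay, compound 4 gives this position a second readable number, and the change from amino to propoxymethyl costs activity: a 4.1-fold higher number from compound 3 to compound 4 (0.61 log units; beyond the scatter). Against the halogens, the result is an at least 1.2-fold lower number from compound 2 to compound 4 (0.10 log units; that floor lies within the scatter) and an at least 1.2-fold lower number from compound 1 to compound 4 (0.10 log units; that floor lies within the scatter), so compound 4 cannot be ranked against either compound. Both comparisons rest on a limit: the limit of > 100000 nM in this assay, at which 2 of the 4 values shown sit.

Still open, going by these compounds, is whether a shorter chain such as methoxymethyl would fall nearer compound 3 or compound 4. The same question stands for a methylamino group or a carboxylic acid at this position.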